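A few compounds are considered here, and "the series" means these few. Any claim that something is new, unique, unknown or untested is made for them only; others in the source may bear on it.

Measured so far in an assay on isolated protein for inhibition of phosphodiesterase 4A (Sus scrofa); on this read-out higher numbers stand for weaker inhibition and lower numbers for stronger inhibition:

Compound 1 `COc1ccc(C(=O)Nc2ccccc2Cl)cc1OC(=O)C(C)(C)C` gives > 1000000 nM, which is a limit of the assay and not a number.
Compound 2 `COc1ccc(/C(S)=N/c2ccccc2Cl)cc1OC1CCCC1` gives 200 nM.
Compound 3 `COc1ccc(C(=O)Nc2ccccn2)cc1OC1CCCC1` gives 1000 nM.

Among the measured compounds shown here, only two of the three values are numbers, and compound 3 holds the higher of them. Its nearest neighbour on this read-out is compound 2, whose lower number lies beyond the usual scatter, so compound 3 is the weaker inhibitor of that pair. Compound 1 sits at the limit recorded under (the limit of > 1000000 nM in this assay, at which 1 of the 3 values shown sits), and nothing more can be read from it.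

Compound 4 `COc1ccc(C(=O)Nc2c(C)nsc2Br)cc1OC1CCCC1` is compound 3 with one change: 5-bromo-3-methyl-1,2-thiazol-4-yl in place of pyridin-2-yl on an amide-type nitrogen. For the measured compounds named here, no measured pair shares this change, so its effect has to be guessed from the structures alone. The pyridin-2-yl ring leaves and a five-membered ring with two hetero atoms and a bromine enters; the shared core and the amide-type nitrogen stay as they are.

Compound 4 is expected to give 500 nM in this assay. Compound 4 is estimated to fall within a range that runs from an expected lower end of 100 nM to an expected upper end of 3000 nM. The expected step is a 2.0-fold lower number from compound 3 to compound 4 (0.30 log units; within the scatter), a modest gain in potency that may well fall within the scatter rather than beyond it.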

Compound 4, half-maximal inhibitory concentration: 500 nM
The estimate for compound 4 equals the measured number at the digits printed; the range from low to high includes it.
By their numbers in this assay, from the lowest: compound 2; then compounds 4 and 3 (each within the scatter of the next). At a limit, above all of these: compound 1.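

In this assay, putting 5-bromo-3-methyl-1,2-thiazol-4-yl in place of pyridin-2-yl on the amide-type nitrogen gives a 2.0-fold lower number from compound 3 to compound 4 (0.30 log units; within the scatter) and so leaves the two compounds indistinguishable on this read-out. Among the compounds shown here, this is the first step that can be read at this position, and it shows that a five-membered aromatic ring with two hetero atoms can stand there in place of a six-membered aromatic ring with one hetero atom with no difference beyond the scatter. Nothing among the measurements offers an explanation for this outcome.

The compounds shown leave open whether the bromine and the methyl on the new ring each matter on their own, or whether a bare 1,2-thiazol-4-yl would give a similar number. They also leave open whether a ring on this nitrogen carrying an amine or a carboxylic acid would shift the number beyond the scatter in either direction, and so how much this position can change inhibition in this assay at all.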